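Alkyne arm replaces methylated alkene on the acid side

The compounds below may be only part of what the source reports. "The series", "measured", "known", "first", "only" and "open" are said of these compounds alone.

Measured in a functional assay for activation of retinoic acid receptor gamma (Homo sapiens); on this read-out higher numbers stand for larger maximal responses and lower numbers for smaller maximal responses:
Compound 1 `CC1(C)CCC(C)(C)c2cc(C(=O)c3ccc(/C=C/C(=O)O)cc3)ccc21`: 86%
Compound 2 `C/C(=C\C(=O)O)c1ccc(C(=O)c2ccc3c(c2)C(C)(C)CCC3(C)C)cc1`: 51%
Compound 3 `C/C(=C\c1ccc(C(=O)c2ccc3c(c2)C(C)(C)CCC3(C)C)cc1)C(=O)O`: 65%

Compound 3 stands second of these three: a number 14 percentage points higher from compound 2 to compound 3 (beyond the scatter), while a number 21 percentage points lower from compound 1 to compound 3 (beyond the scatter). Compound 4 `CC1(C)CCC(C)(C)c2cc(C(=O)c3ccc(C#CC(=O)O)cc3)ccc21` differs from compound 3 in one place: 2-carboxyethynyl in place of 2-carboxyprop-1-en-1-yl on an aromatic carbon. For the measured compounds named here, the only steps that bear on it are those around the acid-bearing arm, where the unsubstituted 2-carboxyethenyl of compound 1 gave the highest number and both methyl-bearing arms fell beyond the scatter below it. Going by the values given here, removing the methyl again while straightening the arm is therefore expected to raise the response, a number 13 percentage points higher from compound 3 to compound 4 (beyond the scatter), though the triple bond has no measured precedent here. Compound 4 is expected to reach about 78%, within 55% to 100%.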

Compound 4, largest response reached (reported as maximum), in percent of the reference or control that the assay uses: 39%
For compound 4 the middle estimate is 39 percentage points above the measured one; the whole stated range lies above it.
By their numbers in this assay, from the lowest: compound 4; then compound 2; then compound 3; then compound 1.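

In this assay, compound 4 gives the lowest number of the four, with a number 26 percentage points lower from compound 3 to compound 4 (beyond the scatter), a number 12 percentage points lower from compound 2 to compound 4 (beyond the scatter) and a number 47 percentage points lower from compound 1 to compound 4 (beyond the scatter). Losing the methyl therefore does not by itself restore the response at this position: compound 1 and compound 4 both lack it, yet their arms, with a double and a triple carbon-carbon bond, give clearly different numbers. Nothing shown here explains the drop. Still open, going by these compounds, is how a 2-carboxyethyl arm, with only single bonds, would compare, and whether an amide in place of the carboxylic acid would keep any response.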